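The source may report more compounds than this note shows. Statements on the series, on what has been measured and on what is new or still open speak of the compounds shown alone.

In a functional assay on the whole organism (artery, strain albino) with Rattus norvegicus as the target, with a stated time of 300 min, at a dose of 10 mg/kg by the oral route (a lower number here means less inhibition, a higher number more inhibition at the dose given (going by the name of the read-out)), compound 1 `CC1=C(C(=O)Nc2ccc(F)cc2)C(c2ccc([N+](=O)[O-])cc2)N=C(SCc2ccccc2)N1` gives 38.5%, and compound 2 `CC1=C(C(=O)Nc2ccc(F)cc2)C(c2ccc([N+](=O)[O-])cc2)N=C(SCc2ccccc2Cl)N1` gives 18.5%. The change between them, (chloro in place of hydrogen on an aromatic carbon), gave a number 20 percentage points lower from compound 1 to compound 2 (beyond the scatter). Compound 3 `CC1=C(C(=O)Nc2ccc(Br)cc2)C(c2ccc(Cl)cc2Cl)N=C(SCc2ccccc2)N1` gives 22.1% in this assay; the difference between the cores of compound 1 and compound 3 is not broken down here. Compound 4 `CC1=C(C(=O)Nc2ccc(Br)cc2)C(c2ccc(Cl)cc2Cl)N=C(SCc2ccccc2Cl)N1` carries the same change on the core of compound 3, (chloro in place of hydrogen on an aromatic carbon), with the same place described for both pairs. The step is expected to run in the same direction as before, since compound 2 showed a number 20 percentage points lower from compound 1 to compound 2 (beyond the scatter), and the expected step is a number 14.1 percentage points lower from compound 3 to compound 4 (beyond the scatter); as compound 3 starts from 22.1%, the room downward is smaller. Compound 4 is therefore estimated at 8%, with a range from 0% to 22%.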

Compound 4, a percentage reported as inhibition, in the whole organism at one dose (the size of the read-out at that dose, not a potency): 36.4%
Estimate against measurement, compound 4: 28.4 percentage points below, and the stated range ends below it.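

On the core of compound 3, benzyl to 2-chlorobenzyl gave a number 14.3 percentage points higher from compound 3 to compound 4 (beyond the scatter). In this assay, the same change therefore does not carry over between these two cores, and its direction reverses: the same change on two cores in this assay, a number 20 percentage points lower (beyond the scatter) from compound 1 to compound 2 and a number 14.3 percentage points higher (beyond the scatter) from compound 3 to compound 4, 34.3 percentage points apart, beyond the scatter of two such steps This shows that the outcome of the change depends on the core, but the two pairs do not show which difference between the cores matters, as those cores differ in more than one place.

Still open, from the compounds shown here alone, is whether the reversal follows the nitrophenyl or dichlorophenyl group, or the fluoro or bromo group on the anilide ring. Also open, going by these compounds, is how a methoxy group or an amine in place of the chloro would behave on either core.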